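This account rests on a few compounds, and the source may have more. Where it says the series, first, only, none or still open, it means among the compounds named here.

Measured compounds in a functional assay on HeLa cells (Homo sapiens) for cytotoxicity, read by CCK-8 assay, with a stated time of 24 h; on this read-out lower numbers stand for stronger inhibition and higher numbers for weaker inhibition:
compound 1 `C/C(=C\c1cc(-c2ccccc2)cs1)C(N)=O` — 12700 nM
compound 2 `C/C(=C\c1cc(-c2ccc(S(C)(=O)=O)cc2)cs1)C(N)=O` — a limit of this assay, > 50000 nM

Compound 2 stands at a limit of this assay rather than at a number, so only a range is known for it. Against compound 1 the step of an at least 3.9-fold higher number from compound 1 to compound 2 (0.59 log units; beyond the scatter) was recorded, and the limit of > 50000 nM in this assay, at which 1 of the 2 values shown sits, shows that this step rests on a limit. Compound 3 `C/C(=C\c1cc(-c2ccc([N+](=O)[O-])cc2)cs1)C(N)=O` differs from compound 2 by nitro in place of methylsulfonyl on an aromatic carbon. Going by the values given here, no measured step covers this exchange; the only measured step, from compound 1 to compound 2, concerns the methylsulfonyl that now leaves, and it ended in a limit, so it sets no direction for compound 3. For compound 3 the expected step is an at least 1.1-fold lower number from compound 2 to compound 3 (0.04 log units; that floor lies within the scatter), meaning no change beyond the scatter. Compound 3 is therefore expected to give 45000 nM in this assay, with a range from 12000 nM to 170000 nM, and quite possibly only another limit.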

Compound 3, half-maximal inhibitory concentration: 2900 nM
Beside the measured number, compound 3's estimate is 16-fold (1.19 log units) above it, outside the stated range (below it).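

In this assay, the exchange on this aromatic carbon, para to a large group, gives an at least 17-fold lower number from compound 2 to compound 3 (1.23 log units; beyond the scatter), so the choice of group here matters even though nitro and methylsulfonyl match in their counts of hydrogen-bond donors and acceptors. Set against hydrogen, nitro gives a 4.4-fold lower number from compound 1 to compound 3 (0.64 log units; beyond the scatter), whereas methylsulfonyl gave an at least 3.9-fold higher number from compound 1 to compound 2 (0.59 log units; beyond the scatter), so a group at this place can move the read-out toward either stronger or weaker inhibition. The exchange from methylsulfonyl to nitro has only a floor for its size, since compound 2 stands at a limit: the limit of > 50000 nM in this assay, at which 1 of the 3 values shown sits.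

The compounds shown leave open what sets the direction of the change at this place. Going by these compounds, whether an amine, a nitrile or a carboxylic acid here would follow nitro or methylsulfonyl also remains open.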